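From isopropyl to cyclopropyl on an amine nitrogen

The compounds below may be only part of what the source reports. "The series", "measured", "known", "first", "only" and "open" are said of these compounds alone.

Values in a functional assay on SW-620 cells (Homo sapiens) for inhibition, read by MTT assay, with a stated time of 72 h (on this read-out lower numbers stand for stronger inhibition and higher numbers for weaker inhibition), for the measured compounds

Compound 1 `CNCc1c(OC)cc(Oc2cccc(Nc3ccccc3)c2)cc1OC` gives 15000 nM
Compound 2 `COc1cc(Oc2cccc(Nc3ccccc3)c2)cc(OC)c1CNCCNC(C)=O` gives 11900 nM
Compound 3 `COc1cc(Oc2cccc(Nc3ccccc3)c2)cc(OC)c1CNC(C)C` gives > 20000 nM as a limit of the assay

Compound 3 has no exact number and rests only on the limit of > 20000 nM in this assay, at which 1 of the 3 values shown sits (a limit, not a measured value). Compound 4 `COc1cc(Oc2cccc(Nc3ccccc3)c2)cc(OC)c1CNC1CC1` differs from compound 3 by one group, with cyclopropyl in place of isopropyl on an amine nitrogen. The most relevant measured evidence comes from other changes at that same nitrogen. Replacing its methyl with isopropyl gave an at least 1.3-fold higher number from compound 1 to compound 3 (0.12 log units; that floor lies within the scatter) and replacing 2-acetamidoethyl with isopropyl gave an at least 1.6-fold higher number from compound 2 to compound 3 (0.22 log units; that floor lies within the scatter) in the data. Extending the chain on that nitrogen gave a 1.3-fold lower number from compound 1 to compound 2 (0.10 log units; within the scatter) as well. None of these steps goes beyond the scatter. For this swap, this assay is therefore expected to show no step beyond the scatter, and compound 4 may again return only a limit. The estimated change is an at least 1.3-fold lower number from compound 3 to compound 4 (0.12 log units; that floor lies within the scatter) and its direction remains uncertain. For compound 4 the estimate is 15000 nM with an expected range from 7000 nM to 28000 nM (an estimate only).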

Compound 4, half-maximal inhibitory concentration: > 20000 nM
Compound 4: no number, only a limit; the forecaster's own chance of this, stated with the estimate: 40%; middle value at least 1.3-fold (0.12 log units) from the limit.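

In this assay, compound 4 returns only a limit, and so does compound 3, so the step between them cannot be read and cyclopropyl and isopropyl on this amine nitrogen cannot be ranked. The two readable steps are an at least 1.6-fold higher number from compound 2 to compound 4 (0.22 log units; that floor lies within the scatter) and an at least 1.3-fold higher number from compound 1 to compound 4 (0.12 log units; that floor lies within the scatter), so neither separates cyclopropyl from 2-acetamidoethyl or from methyl. What is new is that a group with a three-membered ring on this nitrogen ends at the same limit as the open-chain isopropyl, which leaves the series with: the limit of > 20000 nM in this assay, at which 2 of the 4 values shown sit.

Going by these compounds, the true values of compound 3 and compound 4 stay unknown, and with them any real difference between the two groups. Also open, on these data alone, is whether a cyclobutyl group, a longer chain or a chain ending in a carboxylic acid on this nitrogen would give an exact number in this assay.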